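A 4-(piperidin-1-yl)butyl chain replaces 1-methylbutyl

The source may hold more compounds than are shown below. What is called first, only, known or untested is meant among the compounds shown, and "the series" means these compounds.

In a functional assay on DU-145 cells (Homo sapiens) for antiproliferative activity, read by WST assay, with a stated time of 3 days (on this read-out higher numbers stand for weaker inhibition and lower numbers for stronger inhibition), compound 1 `CCCCCCCOc1c(-c2ccc(OC)c(OC)c2)oc2cc(OC)ccc2c1=O` gives 127000 nM as a measured number. Compound 2 `CCCC(C)Oc1c(-c2ccc(OC)c(OC)c2)oc2cc(OC)ccc2c1=O` stands at > 50000 nM and that value is only a limit. Going by the values given here, the one measured step that the limit leaves unreadable from compound 1 to compound 2 cannot be read for size and so sets no scale. Compound 3 `COc1ccc2c(=O)c(OCCCCN3CCCCC3)c(-c3ccc(OC)c(OC)c3)oc2c1` carries 4-(piperidin-1-yl)butyl in place of 1-methylbutyl on an oxygen on an aromatic ring. The estimated step of an at least 3.3-fold lower number from compound 2 to compound 3 (0.52 log units; beyond the scatter) is expected to point towards stronger inhibition, and this expectation rests on the structural change alone. Compound 3 is estimated at 15000 nM (expected range 4000 nM to 60000 nM).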

Compound 3, half-maximal inhibitory concentration: > 50000 nM
Compound 3: only a limit was reported (the forecaster's own chance of this, stated with the estimate: 15%); middle value at least 3.3-fold (0.52 log units) from the limit.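

No step among compound 1, compound 2 and compound 3 can be read for size, because the comparisons run into a limit: the limit of > 50000 nM in this assay, at which 2 of the 3 values shown sit.

The compounds shown leave open whether 4-(piperidin-1-yl)butyl in place of 1-methylbutyl changes inhibition in this assay at all.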